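The source may hold more compounds than are shown below. What is called first, only, known or untested is meant among the compounds shown, and "the series" means these compounds.

Series notes, step from compound 3 to compound 4. Measured so far in a functional assay on HCT-116 cells (Homo sapiens) for antiproliferative activity, read by MTT assay, with a stated time of 72 h; a lower number here means a stronger inhibitor, a higher number a weaker inhibitor:

- compound 1 `NC1=NC2(CCOCC2)N(OCCCOc2cccc(Cl)c2)C(N)=N1` gives 120 nM
- compound 2 `NC1=NC2(CCOCC2)N(OCCCOc2ccc(Cl)c(Cl)c2)C(N)=N1` gives 90 nM
- compound 3 `NC1=NC2(CCOCC2)N(OCCCOc2cc(Cl)c(Cl)cc2Cl)C(N)=N1` gives 2750 nM

Compound 3 carries the highest number of the three: its nearest neighbour is compound 1 and its furthest compound 2, both far outside the scatter. The steps that lead to it are large: a 23-fold higher number from compound 1 to compound 3 (1.36 log units; beyond the scatter) and a 31-fold higher number from compound 2 to compound 3 (1.49 log units; beyond the scatter), whereas a 1.3-fold lower number from compound 1 to compound 2 (0.12 log units; within the scatter).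

Compound 4 `Cc1ccc(OCCCON2C(N)=NC(N)=NC23CCOCC3)cc1` is not yet measured. It differs from compound 3 as follows: 4-methylphenyl in place of 2,4,5-trichlorophenyl on an oxygen on a saturated carbon. For the measured compounds named here, no measured step shows a methyl on this ring, so the guide is only that the two lighter chlorophenyl analogues, compound 1 and compound 2, sit near one another and far from compound 3. A single substituent on the ring, as in compound 4, is therefore expected to bring the number back towards those of compound 1 and compound 2, a decrease well beyond the scatter, though the exact placing of a 4-methylphenyl is uncertain.

Estimate: compound 4 is expected at 200 nM, range 60 nM to 800 nM, meaning an expected step of a 14-fold lower number from compound 3 to compound 4 (1.14 log units; beyond the scatter).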

Compound 4, half-maximal inhibitory concentration: 2390 nM
Compound 4: the middle estimate sits 12-fold (1.08 log units) below what was measured; the whole stated range lies below it.
By their numbers in this assay, from the lowest: compounds 2 and 1 (each within the scatter of the next); then compounds 4 and 3 (each within the scatter of the next).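

In this assay the number of substituents on the ring does not settle the outcome at this oxygen: 4-methylphenyl carries a single substituent, as the 3-chlorophenyl group does, yet the change gives a 20-fold higher number from compound 1 to compound 4 (1.30 log units; beyond the scatter) and, against the 3,4-dichlorophenyl group, a 27-fold higher number from compound 2 to compound 4 (1.42 log units; beyond the scatter) in the same direction. With a 1.2-fold lower number from compound 3 to compound 4 (0.06 log units; within the scatter) as the remaining step, compound 4 stands level with compound 3, so the high numbers are no longer confined to the 2,4,5-trichlorophenyl group. No available data account for this result.

The compounds shown leave open whether the low numbers of compound 1 and compound 2 depend on chlorine as such, which a plain phenyl or a methoxyphenyl group would help to decide. They also leave open how a longer chain would read with each of these aryl groups.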